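The source may hold more compounds than are shown below. What is called first, only, known or untested is meant among the compounds shown, and "the series" means these compounds.

Of the compounds shown here, three sharing one core have been tested in a functional assay on HepG2 cells (Homo sapiens) for cytotoxicity, read by MTT assay, with a stated time of 72 h; a lower number here means a stronger inhibitor, a higher number a weaker inhibitor. Compound 3 `CNC(=O)c1cc(Oc2ccc(C3=NNC(c4ccc(OC)cc4)C3)cc2)ccn1`, with a 4-methoxyphenyl group, gives 9640 nM. Compound 1 `CNC(=O)c1cc(Oc2ccc(C3=NNC(c4ccc(F)cc4Cl)C3)cc2)ccn1`, with a 2-chloro-4-fluorophenyl group, gives 11500 nM, and the step between them is a 1.2-fold lower number from compound 1 to compound 3 (0.08 log units; within the scatter), so the two cannot be told apart. Compound 2 `CNC(=O)c1cc(Oc2ccc(C3=NNC(c4ccc([N+](=O)[O-])cc4)C3)cc2)ccn1`, with a 4-nitrophenyl group, gives > 50000 nM, which is a limit of the assay and not a number. Both other compounds stand apart from it, with an at least 4.3-fold higher number from compound 1 to compound 2 (0.63 log units; beyond the scatter) and an at least 5.1-fold lower number from compound 2 to compound 3 (0.71 log units; beyond the scatter).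

Compound 4 `CNC(=O)c1cc(Oc2ccc(C3=NNC(c4ccc(Br)cc4)C3)cc2)ccn1` has bromo in place of methoxy on an aromatic carbon, para to a large group: bromo in place of methoxy on an aromatic carbon. Going by the values given here, no measured step makes exactly this change. Compound 1 is the nearest guide, as its group also bears halogens, and a 1.2-fold lower number from compound 1 to compound 3 (0.08 log units; within the scatter) suggests no shift beyond the scatter. Compound 2 is a warning that this group can matter, with an at least 5.1-fold lower number from compound 2 to compound 3 (0.71 log units; beyond the scatter). The expected change is a 1.2-fold higher number from compound 3 to compound 4 (0.10 log units; within the scatter). For compound 4 the estimated value is 12000 nM, with an expected range from 5000 nM to 35000 nM.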

Compound 4, half-maximal inhibitory concentration: 57600 nM
Compound 4: the middle estimate sits 4.8-fold (0.68 log units) below what was measured; measured number outside the range, above it.
By their numbers in this assay, from the lowest: compounds 3 and 1 (each within the scatter of the next); then compound 4.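

Until now only the nitro group of compound 2 had set a compound apart, so a change at this position could look harmless unless that particular group was involved, yet in this assay a single bromo para to a large group also moves the result, with a 6.0-fold higher number from compound 3 to compound 4 (0.78 log units; beyond the scatter). A halogen on this phenyl ring does not by itself keep a compound level with compound 1, since the 4-bromophenyl group gives a 5.0-fold higher number from compound 1 to compound 4 (0.70 log units; beyond the scatter). Compound 2 carries a limit and not a number, so its step to compound 4 cannot be read: the limit of > 50000 nM in this assay, at which 1 of the 4 values shown sits.

From the compounds shown here alone, it remains open whether a lone chloro or fluoro in the same place would read like bromo or like methoxy. An amine or a carboxylic acid there is also untested among the compounds shown, so the range of this position is still unknown.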